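Replacing carboxy with (pyrrolidin-1-yl)methyl

The compounds below may be only part of what the source reports. "The series", "measured", "known", "first", "only" and "open" are said of these compounds alone.

In a functional assay on MCF7 cells (Homo sapiens) for antiproliferative activity, read by MTT assay, with a stated time of 48 h (a higher number here means a weaker inhibitor, a lower number a stronger inhibitor), compound 3 `CC(C)=CCC[C@]1(C)/C=C/[C@@H](OC(=O)C=C(C)C)[C@](C)(O)/C=C/C(=O)/C(C(=O)O)=C\C1` gives 16100 nM as its half-maximal inhibitory concentration. That value lies within the scatter of compound 2 `CO[C@]1(C)/C=C/C(=O)/C(CO)=C\C[C@](C)(CCC=C(C)C)/C=C/[C@H]1OC(=O)C=C(C)C` at 14300 nM in the same test, while compound 1 `CC(=O)O[C@]1(C)/C=C/C(=O)/C(CO)=C\C[C@](C)(CCC=C(C)C)/C=C/[C@H]1OC(=O)C=C(C)C` has a clearly lower number (2320 nM).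

Compound 4 `CC(C)=CCC[C@]1(C)/C=C/[C@@H](OC(=O)C=C(C)C)[C@](C)(O)/C=C/C(=O)/C(CN2CCCC2)=C\C1` carries (pyrrolidin-1-yl)methyl in place of carboxy on a double-bonded ring carbon and keeps the rest of compound 3 unchanged. Among the measured compounds shown here, no measured step touches the carboxy group. For the measured compounds named here, the only step available is a 6.2-fold higher number from compound 1 to compound 2 (0.79 log units; beyond the scatter) for methyl in place of acetyl on an oxygen on a saturated carbon, so it offers only a rough guide to the size of a single change.

Neither compound 1 (2320 nM) nor compound 2 (14300 nM) has the carboxy group. Compound 1 hints at a lower number without it, but compound 2 goes against that hint.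

A modest, uncertain a 2.7-fold lower number from compound 3 to compound 4 (0.43 log units; beyond the scatter) is therefore expected in this assay. The estimate for compound 4 is 6000 nM (expected range 1800 nM to 20000 nM).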

Compound 4, half-maximal inhibitory concentration: 220 nM
Compound 4: middle estimate off by 27-fold (1.44 log units), on the high side, outside the stated range (below it).
By their numbers in this assay, from the lowest: compound 4; then compound 1; then compounds 2 and 3 (each within the scatter of the next).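

In this assay, among the compounds shown here, putting (pyrrolidin-1-yl)methyl in place of carboxy gives a 73-fold lower number from compound 3 to compound 4 (1.86 log units; beyond the scatter), which is a much larger change than the only earlier step, a 6.2-fold higher number from compound 1 to compound 2 (0.79 log units; beyond the scatter). For the compounds shown here, this is the first measured step at the double-bonded ring carbon, and it shows that one change here, with the rest of compound 3 kept, can move the number strongly. Nothing given here explains the size of this step.

The step removes carboxy and brings in a nitrogen-bearing ring at the same time, so the compounds shown cannot separate the loss of one from the gain of the other. On these data alone, it also remains open whether an open-chain amine such as (dimethylamino)methyl, or a methyl ester, on this carbon would give a number nearer to that of compound 4 or of compound 3.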